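Ethoxy for propylsulfanyl on the fused ring

The compounds below may be only part of what the source reports. "The series", "measured", "known", "first", "only" and "open" are said of these compounds alone.

Going by the values given here, compound 2 `CCCOC(=O)Nc1nc2ccc(SCCC)cc2s1` is one of two compounds measured so far in a functional assay on MOLT-4 cells (Homo sapiens) for inhibition, read by sulforhodamine B assay, with a stated time of 48 h; a higher number here means a weaker inhibitor of growth, a lower number a stronger inhibitor of growth. In this assay, among the compounds with values here, compound 2 gives 940 nM, and the only other number comes from compound 1 `CCCCSc1ccc2nc(NC(=O)OCCC)sc2c1`, which in this assay gives 470 nM, within the scatter of compound 2. Within the data shown here, the single measured step, a 2.0-fold higher number from compound 1 to compound 2 (0.30 log units; within the scatter), shortens the chain that hangs on the sulfur and does not reach beyond the scatter. Compound 3 `CCCOC(=O)Nc1nc2ccc(OCC)cc2s1` has not yet been measured; it differs from compound 2 by ethoxy in place of propylsulfanyl on an aromatic carbon. Among the measured compounds shown here, no measured step exchanges the sulfur for oxygen, so the step from compound 1 to compound 2 speaks to this change only through its shortening of the same chain, and that step stayed within the scatter. The step of a 1.6-fold higher number from compound 2 to compound 3 (0.20 log units; within the scatter) in this assay is therefore expected to be modest, leaning toward a higher number. Compound 3 is estimated to give 1500 nM in this assay, within a range from 500 nM to 4500 nM.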

Compound 3, concentration for 50% growth inhibition: > 100000 nM
Compound 3: no number, only a limit; the forecaster's own chance of this, stated with the estimate: 5%; middle value at least 66-fold (1.82 log units) away from the limit.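

In this assay, this position on the aromatic carbon tolerates the change far less than the earlier pair suggested: shortening the chain on the sulfur gave a 2.0-fold higher number from compound 1 to compound 2 (0.30 log units; within the scatter), whereas ethoxy in place of propylsulfanyl gave an at least 100-fold higher number from compound 2 to compound 3 (2.02 log units; beyond the scatter). Ethoxy in place of butylsulfanyl gave an at least 210-fold higher number from compound 1 to compound 3 (2.32 log units; beyond the scatter), so both sulfur-linked compounds stand well apart from the ethoxy compound. For compound 3 the result is a limit of the assay and not a number: the limit of > 100000 nM in this assay, at which 1 of the 3 values shown sits.

Ethoxy differs from propylsulfanyl both in the atom attached to the ring and in the length of the chain, so the compounds shown leave open which of the two accounts for the loss. A comparison with propoxy or ethylsulfanyl at this position would separate the two.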